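A Methylphenyl Replaces a Halogenated Ring on the Shared Core

The source may report more compounds than this note shows. Statements on the series, on what has been measured and on what is new or still open speak of the compounds shown alone.

Of the compounds shown here, two built on one shared core have so far been tested in a functional assay on HT-1080 cells (Homo sapiens) for cytotoxicity, read by MTT assay, with a stated time of 24 h; on this read-out lower numbers stand for stronger inhibition and higher numbers for weaker inhibition. Compound 1 `c1ccc(CNC(c2ccc[nH]2)c2nnc(-c3ccccc3)o2)cc1` gives 231000 nM in this assay, while compound 2 `Fc1cc(-c2nnc(C(NCc3ccccc3)c3ccc[nH]3)o2)c(Cl)cc1Cl` gives 25600 nM. Within the data shown here, compound 2 thus holds the lowest of the two numbers, and the only measured step, a 9.0-fold lower number from compound 1 to compound 2 (0.96 log units; beyond the scatter), separates it from compound 1.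

Compound 3 `Cc1cccc(-c2nnc(C(NCc3ccccc3)c3ccc[nH]3)o2)c1` differs from compound 2 in a single place: 3-methylphenyl in place of 2,4-dichloro-5-fluorophenyl on an aromatic carbon. Among the measured compounds shown here, the one measured step that bears on this exchange is a 9.0-fold lower number from compound 1 to compound 2 (0.96 log units; beyond the scatter), where a plain phenyl gave the higher number and the halogenated ring the lower one. A 3-methylphenyl is neither of these, so a move back toward the number of compound 1 is expected, though probably not the whole way. The expected step is a 4.7-fold higher number from compound 2 to compound 3 (0.67 log units; beyond the scatter). Compound 3 is therefore estimated at about 120000 nM, within a likely range from 40000 nM to 300000 nM.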

Compound 3, half-maximal inhibitory concentration: 311000 nM
Beside the measured number, compound 3's estimate is 2.6-fold (0.41 log units) below it, and the stated range ends below it.
By their numbers in this assay, from the lowest: compound 2; then compounds 1 and 3 (each within the scatter of the next).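

In this assay, 3-methylphenyl in place of 2,4-dichloro-5-fluorophenyl on this aromatic carbon of the shared core gives a 12-fold higher number from compound 2 to compound 3 (1.08 log units; beyond the scatter) and removes the whole advantage of the halogenated ring. Methyl in place of hydrogen on the phenyl gives a 1.3-fold higher number from compound 1 to compound 3 (0.13 log units; within the scatter) and so cannot be told apart from the plain phenyl, leaving 2,4-dichloro-5-fluorophenyl as the only one of these three groups that stands apart. Nothing measured here accounts for the gap between the halogenated ring and the other two.

On these data alone, whether a single chlorine or a single fluorine on the phenyl would be enough to match the low number of compound 2 stays open. So does the outcome of a different kind of group on that phenyl, such as an amine or a carboxylic acid.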